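Halogen swap on the hydrazone series in the J774 cell assay

The source may hold more compounds than are shown below. What is called first, only, known or untested is meant among the compounds shown, and "the series" means these compounds.

Two members of this series have been taken through an ADME assay on J774 cells (Mus musculus) for cytotoxicity, read by MTT assay, with a stated time of 48 h, tested at 50 ug/mL (on this read-out lower numbers stand for a stronger effect and higher numbers for a weaker effect at the one concentration tested), so far. Compound 1, `O=C(N/N=C/c1cccc(Cl)c1)c1cnccn1`, gives 100%. Compound 2, `O=C(N/N=C/c1ccccc1Br)c1cnccn1`, gives 98%. The two numbers lie within the scatter of each other, so on this read-out neither compound is distinguishable from the other: both point to a weak effect at the single concentration tested. Among the measured compounds shown here, compound 1 thus stands with the only other measured compound at the weak end of the scale.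

The next compound, compound 3, `O=C(N/N=C/c1cccc(Br)c1)c1cnccn1`, keeps the shared core of compound 1 and differs from it in one place: bromo in place of chloro on an aromatic carbon. For the measured compounds named here, no step between two measured compounds addresses this change, so the expectation rests on the two values shown, both of which sit close together in this assay. From compound 1 to compound 3 the step is expected to be a number 2 percentage points lower from compound 1 to compound 3 (within the scatter), that is, none beyond the scatter. Compound 3 is therefore estimated to give 98% in this assay. For compound 3 the expected range runs from 88% to 105%.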

Compound 3, a percentage reported as activity, at one concentration (the size of the read-out at that concentration, not a potency): 100%
Compound 3: middle estimate off by 2 percentage points, on the low side; low and high end bracket the measured number.
By their numbers in this assay, from the lowest: compounds 2, 1 and 3 (each within the scatter of the next).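

Bromo in place of chloro on an aromatic carbon, meta to a large group, gives no change at the digits printed from compound 1 to compound 3 (within the scatter) in this assay, which is the first comparison in the series that isolates a single change. At this position, the exchange of one halogen for the other therefore leaves the read-out indistinguishable at the one concentration tested, and both compounds remain at the weak end of the scale, a statement that applies only to this pair and this swap. No measured evidence bears on why the read-out stays put across this change, so the result stands as an observation without an explanation.

The compounds shown leave open whether any replacement at this aromatic carbon can move the read-out beyond the scatter, since an amine, a carboxylic acid or a methoxy group there would be a much larger departure from chloro and bromo than the swap of one halogen for another. They also leave open whether compound 1 and compound 3 would still match at another concentration or exposure time.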